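Adding a hydroxy group to compound 3

The source may hold more compounds than are shown below. What is called first, only, known or untested is meant among the compounds shown, and "the series" means these compounds.

Of the compounds shown here, three of one series have so far been tested in a functional assay on MDA-MB-231 cells (Homo sapiens) for cytotoxicity, read by MTT assay; a higher number here means a weaker inhibitor, a lower number a stronger inhibitor. Compound 1 `COc1cc(OC)cc(-n2cc(-c3ccc(OC)c(O)c3)nn2)c1` gives > 10000 nM in this assay, a limit of the assay rather than a number. Compound 2 `COc1cc(-n2cc(-c3ccc(N)cc3)nn2)cc(OC)c1OC` gives > 10000 nM in this assay, again only a limit. Compound 3 `COc1ccc(-c2cn(-c3cc(OC)c(OC)c(OC)c3)nn2)cc1` gives > 10000 nM in this assay, also a limit. Within the data shown here, the only pair that differs in one place is compound 2 and compound 3, methoxy in place of amino on an aromatic carbon, and there the step reads a step that the two limits leave unreadable from compound 2 to compound 3. Compound 3 therefore stands at the limit of > 10000 nM in this assay, at which 3 of the 3 values shown sit, and nothing among the three measured compounds gives a step whose size can be read.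

Compound 4 `COc1ccc(-c2cn(-c3cc(OC)c(OC)c(OC)c3)nn2)cc1O` differs from compound 3 by hydroxy in place of hydrogen on an aromatic carbon. Among the measured compounds shown here, no measured step bears on this change: compound 1, which also carries a hydroxy group on the ring that bears a methoxy, sits at the limit like the others, so its pairing with compound 3 is not a single-point step and its value shows only that limit. With every value at the limit, the step in this assay from compound 3 to compound 4 is expected to be a step that the limit leaves unreadable from compound 3 to compound 4, none readable beyond the scatter. Compound 4 is expected to give about 15000 nM in this assay, between 4000 nM and 60000 nM, most likely again reported only as a limit.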

Compound 4, half-maximal inhibitory concentration: > 10000 nM
Compound 4 was reported as a limit (the forecaster's own chance of this, stated with the estimate: 80%); the middle value is on the limit's open side.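

Neither the comparison of compound 3 with compound 4 nor that of compound 1 with compound 4 gives a step that can be read, because every value is only a limit: the limit of > 10000 nM in this assay, at which 4 of the 4 values shown sit.

The compounds shown leave open how large these hydroxy and methoxy changes are in this assay, and which structural change would bring a value within measurable range.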